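Adding a methoxy group to a pyrazoline-bearing pyrimidinone series

This account rests on a few compounds, and the source may have more. Where it says the series, first, only, none or still open, it means among the compounds named here.

Of the compounds shown here, three sharing one core have been tested in a functional assay on HT-29 cells (Homo sapiens) for antiproliferative activity, with a stated time of 72 h; a higher number here means a weaker inhibitor, a lower number a stronger inhibitor. Compound 1, `COc1ccc(C2CC(c3ccc(Cl)cc3)=NN2c2nc(-c3ccccc3)c(C#N)c(=O)n2C)cc1`, gives 9120 nM in this assay. Compound 2, `COc1ccc(C2CC(c3ccccc3)=NN2c2nc(-c3ccc(Cl)cc3)c(C#N)c(=O)n2C)cc1`, gives 11000 nM. Compound 3, `Cn1c(N2N=C(c3ccc(Cl)cc3)CC2c2ccccc2)nc(-c2ccc(Cl)cc2)c(C#N)c1=O`, gives 8720 nM, a number that sits within the usual scatter of both compound 1 and compound 2; the three results cannot be told apart with confidence, and none of the compounds can be called more or less potent than another.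

Compound 4, `COc1ccc(C2CC(c3ccc(Cl)cc3)=NN2c2nc(-c3ccc(Cl)cc3)c(C#N)c(=O)n2C)cc1`, has not yet been measured in this assay. It differs from compound 3 in one place: methoxy in place of hydrogen on an aromatic carbon. Compounds 1 and 2 already carry this methoxy-bearing ring, and their numbers in this assay lie within the scatter of compound 3. On that basis the step from compound 3 to compound 4 is expected to be small, without a clear direction and not beyond the scatter, as shown by a 1.1-fold higher number from compound 3 to compound 4 (0.04 log units; within the scatter). Compound 4 is therefore estimated to give 9500 nM in this assay. The expected range for compound 4 runs from 4500 nM to 20000 nM.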

Compound 4, half-maximal inhibitory concentration: 15100 nM
The estimate for compound 4 lay 1.6-fold (0.20 log units) below the measured number; the measured number falls inside the stated range.
By their numbers in this assay, from the lowest: compounds 3, 1, 2 and 4 (each within the scatter of the next).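

In this assay the change from phenyl to 4-methoxyphenyl can now be read directly as a 1.7-fold higher number from compound 3 to compound 4 (0.24 log units; within the scatter) and this first single-place step at this position stays within the scatter, so the methoxy group cannot be said to move the number in either direction. The two steps that add a chloro group to a compound already carrying the methoxy, a 1.4-fold higher number from compound 2 to compound 4 (0.14 log units; within the scatter) and a 1.7-fold higher number from compound 1 to compound 4 (0.22 log units; within the scatter) also stay within the scatter, which means that none of the three single changes leading to compound 4 can be told from repeat-measurement noise in this small set. No other measurement here helps to explain why these numbers lie so close together.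

On these data alone, it remains open whether a different group at this spot, such as an amine, a carboxylic acid or a longer chain like butoxy, would give a step beyond the scatter. The compounds shown also leave open whether a methoxy group placed elsewhere on this ring, or on either of the other two aromatic rings, would behave the same way.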